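The compounds below may be only part of what the source reports. "The series", "measured", "known", "first", "only" and "open" are said of these compounds alone.

Measured so far in an ADME assay on Huh-5-2 cells (Homo sapiens) for cytotoxicity, read by WST assay, with a stated time of 3 days; on this read-out higher numbers stand for lower toxicity in this test and lower numbers for higher toxicity in this test:
compound 1, `N#Cc1cccc(COc2c(-c3ccccc3)oc3cc(O)cc(O)c3c2=O)c1` — 21000 nM
compound 2, `Cc1cccc(COc2c(-c3ccccc3)oc3cc(O)cc(O)c3c2=O)c1` — 29000 nM

Compound 2 and compound 1 share a core and differ only in the group on the benzyl ring; in this assay their numbers lie within the usual scatter of one another, as the step from one to the other shows: a 1.4-fold higher number from compound 1 to compound 2 (0.14 log units; within the scatter). Compound 3, `COc1cccc(COc2c(-c3ccccc3)oc3cc(O)cc(O)c3c2=O)c1`, has not yet been measured in this assay. Its structure differs from compound 2 in one place: methoxy in place of methyl on an aromatic carbon.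

Among the compounds with values here, the only measured step that bears on this change is the one from compound 1 to compound 2, which exchanged cyano for methyl on the same aromatic carbon and stayed within the scatter. Within the data shown here, a change from methyl to methoxy at that same position is of similar kind, and no measured pair shows that this position moves the cytotoxic concentration by more than the scatter. The expected step from compound 2 to compound 3 is therefore small, with no direction beyond the scatter: a 1.1-fold lower number from compound 2 to compound 3 (0.03 log units; within the scatter). In this assay compound 3 is estimated at 27000 nM, with a range from 13000 nM to 55000 nM.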

Compound 3, half-maximal cytotoxic concentration: 28000 nM
Estimate against measurement, compound 3: 1.0-fold (0.02 log units) below; measured number inside the range.
By their numbers in this assay, from the lowest: compounds 1, 3 and 2 (each within the scatter of the next).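

In this assay, methoxy in place of methyl on this aromatic carbon, meta to a large group, gives a 1.0-fold lower number from compound 2 to compound 3 (0.02 log units; within the scatter), and methoxy in place of cyano at the same carbon gives a 1.3-fold higher number from compound 1 to compound 3 (0.12 log units; within the scatter). Where the earlier compounds offered a single comparison at this position, three groups can now be set against one another there, and all three pairs lie within the scatter, so the oxygen that methoxy brings, with its hydrogen-bond acceptor, leaves no readable mark on the number in this test. No supporting measurement is available to say why these three groups read alike.

As far as these compounds go, whether this position stays as undemanding with groups of a different kind, such as an amine, a carboxylic acid or a longer chain, remains open. Also open, from the compounds shown here alone, is whether methyl, methoxy and cyano would read alike on other carbons of this ring, or on a compound whose core differs from the shared core of these three.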